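The source may hold more compounds than are shown below. What is called first, only, known or untested is meant among the compounds shown, and "the series" means these compounds.

Among the compounds with values here, in a physicochemical assay, with a stated time of 6 min (on this read-out higher numbers stand for weaker inhibition and lower numbers for stronger inhibition), compound 1 `O=C(Nc1nc(-c2cc3ccccc3o2)cs1)Nc1ccccc1F` gives 2630 nM, the only plain number in the set. Compound 2 `O=C(Nc1nc(-c2cc3cc(Br)ccc3o2)cs1)Nc1ccccc1F` returns a limit of the assay, > 200000 nM. Compound 3 `O=C(Nc1ccc(F)cc1)Nc1nc(-c2cc3cc(Br)ccc3o2)cs1` likewise returns a limit, > 200000 nM. Within the data shown here, the one readable step, an at least 76-fold higher number from compound 1 to compound 2 (1.88 log units; beyond the scatter), follows bromo in place of hydrogen on an aromatic carbon; the step that the two limits leave unreadable from compound 2 to compound 3 cannot be read, as both of its ends sit at the limit of > 200000 nM in this assay, at which 2 of the 3 values shown sit. Compound 4 `Cc1ccc(NC(=O)Nc2nc(-c3cc4ccccc4o3)cs2)cc1` differs from compound 1 by 4-methylphenyl in place of 2-fluorophenyl on an amide-type nitrogen. Among the measured compounds shown here, no measured step covers a change of this kind, so for compound 4 in this assay no step beyond the scatter is expected: a 1.1-fold higher number from compound 1 to compound 4 (0.06 log units; within the scatter). Compound 4 is therefore estimated at 3000 nM, with a range from 800 nM to 12000 nM.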

Compound 4, half-maximal inhibitory concentration: 500 nM
Compound 4: middle estimate off by 6.0-fold (0.78 log units), on the high side; the measured number lies below the stated range.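

The aryl group on the amide-type nitrogen matters on the core of compound 1: in this assay, 4-methylphenyl in place of 2-fluorophenyl gives a 5.3-fold lower number from compound 1 to compound 4 (0.72 log units; beyond the scatter). This is the only readable step at this position, since the step between the two bromo compounds cannot be read because both ends sit at a limit: the limit of > 200000 nM in this assay, at which 2 of the 4 values shown sit.

The compounds shown do not separate losing the 2-fluorophenyl group from gaining the 4-methylphenyl group. Plain phenyl or cyclohexyl on this nitrogen remains open, as does whether the step holds on other cores.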